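The source may hold more compounds than are shown below. What is called first, only, known or untested is meant among the compounds shown, and "the series" means these compounds.

In a functional assay on MCF7 cells (Homo sapiens) for inhibition, read by MTT assay, with a stated time of 72 h (on this read-out higher numbers stand for weaker inhibition and lower numbers for stronger inhibition), compound 1 `Cc1cc2occ(-c3nc(-c4ccccc4)c(-c4ccccc4)n3-c3ccc([N+](=O)[O-])cc3)c(=O)c2cc1Cl` gives 6250 nM, and compound 2 `Cc1cc2occ(-c3nc(-c4ccccc4)c(-c4ccccc4)n3-c3ccc(Cl)c(Cl)c3)c(=O)c2cc1Cl` gives 1560 nM, the lower of the two numbers. Compound 3 `Cc1ccc(-n2c(-c3coc4cc(C)c(Cl)cc4c3=O)nc(-c3ccccc3)c2-c2ccccc2)cc1` differs from compound 2 in one group: 4-methylphenyl in place of 3,4-dichlorophenyl on an aromatic nitrogen. It has 4-methylphenyl in place of 3,4-dichlorophenyl on an aromatic nitrogen. Within the data shown here, the only measured change at this place is modest: a 4.0-fold lower number from compound 1 to compound 2 (0.60 log units; beyond the scatter). Among the measured compounds shown here, no measured compound carries 4-methylphenyl, so the direction is uncertain, but a step of similar or smaller size towards a higher number is expected in this assay. The estimated change is a 1.9-fold higher number from compound 2 to compound 3 (0.28 log units; within the scatter). For compound 3, the expected value is 3000 nM, within an estimated range of 1000 nM to 9000 nM.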

Compound 3, half-maximal inhibitory concentration: 12500 nM
Estimate against measurement, compound 3: 4.2-fold (0.62 log units) below; measured number outside the range, above it.
By their numbers in this assay, from the lowest: compound 2; then compounds 1 and 3 (each within the scatter of the next).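

In this assay, 4-methylphenyl in place of 3,4-dichlorophenyl on the aromatic nitrogen gives an 8.0-fold higher number from compound 2 to compound 3 (0.90 log units; beyond the scatter) and so loses what the dichloro group had gained. Methyl in place of nitro gives a 2.0-fold higher number from compound 1 to compound 3 (0.30 log units; within the scatter) and leaves compound 1 and compound 3 indistinguishable, so among these three groups only 3,4-dichlorophenyl stands apart. No evidence here explains this difference. Still open, from the compounds shown here alone, is whether a single chlorine, as in 4-chlorophenyl, would keep the lower number of compound 2, and how an amine or a carboxylic acid on this phenyl ring would read.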